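Replacing Tert-Butyl With a Second 2-(Methoxycarbonyl)ethenyl Group

The compounds below may be only part of what the source reports. "The series", "measured", "known", "first", "only" and "open" are said of these compounds alone.

Compound 1 `COC(=O)/C=C/c1cccc(N(Cc2ccc(-c3cccc(Cl)c3)cc2)C(=O)C2CCCCC2)c1` and compound 2 `COC(=O)/C=C/c1cccc(N(Cc2ccc(C(C)(C)C)cc2)C(=O)C2CCCCC2)c1` share one core and differ only in the group carried by the benzyl ring. In an assay on isolated protein with Bile acid receptor (Homo sapiens) as the target (on this read-out lower numbers stand for an effect already at smaller amounts and higher numbers for an effect only at larger amounts of compound), compound 1 gives 94 nM. For compound 2 the result in this assay is reported only as a limit, > 1000 nM, not as a number. The exchange produces an at least 10-fold higher number from compound 1 to compound 2 (1.02 log units; beyond the scatter), so compound 2 stands at the weak end of the two measured values, its reading sitting at the limit of > 1000 nM in this assay, at which 1 of the 2 values shown sits.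

Compound 3 `COC(=O)/C=C/c1ccc(CN(C(=O)C2CCCCC2)c2cccc(/C=C/C(=O)OC)c2)cc1` arises from compound 2 through (2-(methoxycarbonyl)ethenyl in place of tert-butyl on an aromatic carbon). Among the compounds with values here, no measured step covers this exchange directly; the single measured step was large and ran toward weaker binding, but it says nothing about what an ester-bearing chain does at this position. Starting from a limit, the expected step in this assay from compound 2 to compound 3 is a step that the limit leaves unreadable from compound 2 to compound 3, which means no change that would stand out beyond the scatter. Compound 3 is therefore estimated at 1500 nM in this assay, with a range from 300 nM to 8000 nM, and a fair chance that only a limit is reported again.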

Compound 3, half-maximal effective concentration: > 1000 nM
Compound 3 was reported as a limit; the forecaster's own chance of this, stated with the estimate: 60%; the middle value is on the limit's open side.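

Compound 1, with its 3-chlorophenyl group, remains the only one of the three with a readable number in this assay, while the 2-(methoxycarbonyl)ethenyl group, like tert-butyl, gives only a limit. Exchanging 3-chlorophenyl for this chain, which brings two hydrogen-bond acceptors and no ring, gives an at least 10-fold higher number from compound 1 to compound 3 (1.02 log units; beyond the scatter), so the acceptors of this chain do not bring back a readable number at this position. The step between compound 2 and compound 3 cannot be read, and neither group can be ranked above the other, as both compounds rest on the same limit: the limit of > 1000 nM in this assay, at which 2 of the 3 values shown sit.

From the compounds shown here alone, how far past that limit compound 2 and compound 3 actually lie remains open, as does the question of whether any group without a ring can give a readable number here. A plain phenyl group would show whether the chlorine of compound 1 contributes to its value, and a carboxylic acid in place of the methyl ester on the ethenyl chain would test this chain in a second form.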